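The source may hold more compounds than are shown below. What is called first, only, known or untested is meant among the compounds shown, and "the series" means these compounds.

Of the compounds shown here, three built on one shared core have been measured in an assay on isolated protein for inhibition of 5-hydroxytryptamine receptor 4 (Homo sapiens); on this read-out lower numbers stand for stronger inhibition and higher numbers for weaker inhibition. Compound 1 `CCN1CCN(S(=O)(=O)CCCN2CCC(CNC(=O)c3cccc4c3OCCO4)CC2)CC1` gives 0.0501 nM. Compound 2 `CCCS(=O)(=O)N1CCN(S(=O)(=O)CCCN2CCC(CNC(=O)c3cccc4c3OCCO4)CC2)CC1` gives 0.1 nM. Compound 3 `O=C(NCC1CCN(CCCS(=O)(=O)N2CCN(S(=O)(=O)c3ccc(F)cc3)CC2)CC1)c1cccc2c1OCCO2` gives 0.0316 nM, the lowest of the numbers seen so far; its nearest neighbour is compound 1, at a 1.6-fold lower number from compound 1 to compound 3 (0.20 log units; within the scatter), while its furthest is compound 2, at a 3.2-fold lower number from compound 2 to compound 3 (0.50 log units; beyond the scatter). The step of a 2.0-fold higher number from compound 1 to compound 2 (0.30 log units; within the scatter) shows that swapping ethyl for propylsulfonyl at this ring nitrogen hardly moves the read-out.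

Compound 4 `O=C(NCC1CCN(CCCS(=O)(=O)N2CCN(c3ccccn3)CC2)CC1)c1cccc2c1OCCO2` differs from compound 3 in that (pyridin-2-yl in place of (4-fluorophenyl)sulfonyl on an amine nitrogen in a ring). Among the measured compounds shown here, none of the measured steps removes the sulfonyl group from this nitrogen altogether, so the change is only partly covered. For the measured compounds named here, what bears on it is that every substituent tried at this position so far has left the number within or just beyond the usual scatter: the within-scatter step a 1.6-fold lower number from compound 1 to compound 3 (0.20 log units; within the scatter) and the modest step of a 3.2-fold lower number from compound 2 to compound 3 (0.50 log units; beyond the scatter). A small step is therefore expected for compound 4 in this assay, probably towards a somewhat higher number, that is a 1.9-fold higher number from compound 3 to compound 4 (0.28 log units; within the scatter). Compound 4 is estimated at 0.06 nM, with a range from 0.02 nM to 0.2 nM.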

Compound 4, inhibition constant: 0.251 nM
Compound 4: the middle estimate sits 4.2-fold (0.62 log units) below what was measured; the measured number lies above the stated range.
By their numbers in this assay, from the lowest: compounds 3, 1 and 2 (each within the scatter of the next, the first and the last beyond it); then compound 4.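

Among the compounds shown here, this position turns out not to be indifferent in this assay: compound 4 has the highest number of the four, and pyridin-2-yl is the first group here to stand beyond the scatter from all the others, with a modest step from each (a 7.9-fold higher number from compound 3 to compound 4 (0.90 log units; beyond the scatter); a 2.5-fold higher number from compound 2 to compound 4 (0.40 log units; beyond the scatter); a 5.0-fold higher number from compound 1 to compound 4 (0.70 log units; beyond the scatter)). Having a six-membered aromatic ring at this amine nitrogen does not by itself keep the number low, since compound 3 and compound 4 both carry one, and losing the sulfonyl group does not by itself raise it, since compound 1 has ethyl there and no sulfonyl group, yet its number is lower than that of compound 4. Nothing measured here on the properties of these groups accounts for the step.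

The compounds shown leave open whether the step goes with the ring nitrogen of pyridin-2-yl or with any aromatic ring placed on this amine nitrogen without a sulfonyl group. A plain phenyl group or a pyridin-4-yl group at the same place would help separate these two readings.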